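The source may report more compounds than this note shows. Statements on the series, on what has been measured and on what is new or still open speak of the compounds shown alone.

In a functional assay on Jurkat cells (Homo sapiens) for inhibition, read by CCK-8 assay, with a stated time of 48 h (on this read-out lower numbers stand for stronger inhibition of growth and higher numbers for weaker inhibition of growth), compound 1 `CN1CCN(c2ccc(Nc3ncc(Cl)c(Nc4ccccc4)n3)nc2)CC1` gives > 100000 nM, which is a limit of the assay and not a number. Compound 2 `CN1CCN(c2ccc(Nc3ncc(Cl)c(NCc4ccc(C(F)(F)F)cc4)n3)nc2)CC1` gives 7960 nM, and compound 3 `COc1ccccc1CNc1nc(Nc2ccc(N3CCN(C)CC3)cn2)ncc1Cl` gives 10800 nM. These two values are close: a 1.4-fold higher number from compound 2 to compound 3 (0.13 log units; within the scatter). Compound 4 `Cc1ccc(Nc2nc(Nc3ccc(N4CCN(C)CC4)cn3)ncc2Cl)cc1` differs from compound 3 as follows: 4-methylphenyl in place of 2-methoxybenzyl on a nitrogen on an aromatic ring. In words, it has 4-methylphenyl in place of 2-methoxybenzyl on a nitrogen on an aromatic ring. Going by the values given here, that brings back a phenyl-type group like the one in compound 1. The closest evidence is the reverse change, which gave large gains: an at least 12-fold lower number from compound 1 to compound 2 (1.09 log units; beyond the scatter), and an at least 9.2-fold lower number from compound 1 to compound 3 (0.96 log units; beyond the scatter). Undoing it should therefore raise the number substantially, and the expected step is a 4.6-fold higher number from compound 3 to compound 4 (0.67 log units; beyond the scatter). For compound 4 the estimated value is 50000 nM, with an expected range of 15000 nM to 100000 nM.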

Compound 4, concentration for 50% growth inhibition: 30900 nM
The estimate for compound 4 lay 1.6-fold (0.21 log units) above the measured number; the range from low to high includes it.
By their numbers in this assay, from the lowest: compounds 2 and 3 (each within the scatter of the next); then compound 4. At a limit, above all of these: compound 1.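

On this nitrogen, a ring bound directly does not rule out growth inhibition: one added methyl on the phenyl of compound 1 gives an at least 3.2-fold lower number from compound 1 to compound 4 (0.51 log units; beyond the scatter). That step has only one firm end, since compound 1 stands at a limit and not a number: the limit of > 100000 nM in this assay, at which 1 of the 4 values shown sits. The benzyl compounds still hold the lower numbers, with a 2.9-fold higher number from compound 3 to compound 4 (0.46 log units; beyond the scatter) and a 3.9-fold higher number from compound 2 to compound 4 (0.59 log units; beyond the scatter).

On these data alone, what an amine or a carboxylic acid on that phenyl ring would do remains open. So does the effect of a phenylethyl group on this nitrogen.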